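Swapping Difluoromethyl for Cyano in Compound 1

This account rests on a few compounds, and the source may have more. Where it says the series, first, only, none or still open, it means among the compounds named here.

Measured in an ADME assay on microsomes from liver (Mus musculus) for metabolic stability; a lower number here means that the compound disappears faster, a higher number that the compound lasts longer:
- Compound 1 `NS(=O)(=O)CC(=O)NCCSc1nonc1/C(=N/O)Nc1ccc(F)c(C(F)F)c1`: 1.07 h
- Compound 2 `CC1(C(=O)NCCSc2nonc2/C(=N/O)Nc2ccc(F)c(C(F)F)c2)CCN1`: 0.268 h
- Compound 3 `CC(C)(O)CC(=O)NCCSc1nonc1/C(=N/O)Nc1ccc(F)c(C(F)F)c1`: 0.175 h

Compound 1 stands highest of these three. Compound 4 `N#Cc1cc(N/C(=N\O)c2nonc2SCCNC(=O)CS(N)(=O)=O)ccc1F` differs from it in one place: cyano in place of difluoromethyl on an aromatic carbon. Within the data shown here, no measured step touches that place. The measured steps instead change the group on the carbonyl carbon, giving a 4.0-fold lower number from compound 1 to compound 2 (0.60 log units; beyond the scatter) and a 6.1-fold lower number from compound 1 to compound 3 (0.79 log units; beyond the scatter). They show that one change can move the half-life noticeably in this small set, but they say nothing about the direction of this swap. A shift beyond the scatter in this assay is therefore not expected, though the uncertainty is wide. The expected size is a 1.1-fold higher number from compound 1 to compound 4 (0.05 log units; within the scatter). For compound 4 the estimated half-life is 1.2 h, with an expected range from 0.4 h to 3 h.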

Compound 4, half-life: 2.38 h
The estimate for compound 4 lay 2.0-fold (0.30 log units) below the measured number; the measured number falls inside the stated range.
By their numbers in this assay, from the lowest: compounds 3 and 2 (each within the scatter of the next); then compound 1; then compound 4.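

The earlier steps shown here changed only the group on the carbonyl carbon, and this result shows that the aromatic carbon also matters for the half-life. In this assay, cyano in place of difluoromethyl gives a 2.2-fold higher number from compound 1 to compound 4 (0.35 log units; beyond the scatter), a change beyond the usual scatter, with the sulfamoyl side chain held constant. Nothing shown here accounts for this rise. As far as these compounds go, whether the same swap raises the half-life with the side chains of compound 2 and compound 3 remains open. So does the outcome with trifluoromethyl, chloro or methyl on this aromatic carbon.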